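This account rests on a few compounds, and the source may have more. Where it says the series, first, only, none or still open, it means among the compounds named here.

Three compounds share one core and differ only in the aryl group held on an oxygen on a saturated carbon. Compound 1 `CC(C)[C@H](NC(=O)COc1cccc2ccccc12)C(=O)N[C@@H](CC(=O)O)C(=O)COc1ccc(-c2ccccc2)cc1` carries a 4-phenylphenyl group, and in a functional assay on Jurkat cells (Homo sapiens) (on this read-out higher numbers stand for weaker inhibition and lower numbers for stronger inhibition), compound 1 gives 87900 nM. Compound 3 `CC(C)[C@H](NC(=O)COc1cccc2ccccc12)C(=O)N[C@@H](CC(=O)O)C(=O)COc1cc(F)c(F)cc1F` carries a 2,4,5-trifluorophenyl group, and in this assay compound 3 gives 39300 nM. Compound 2 `CC(C)[C@H](NC(=O)COc1cccc2ccccc12)C(=O)N[C@@H](CC(=O)O)C(=O)COc1ccccc1[N+](=O)[O-]` carries a 2-nitrophenyl group. For compound 2 this assay reports only a limit, > 100000 nM, not a measured number, so compound 2 sits at the limit of > 100000 nM in this assay, at which 1 of the 3 values shown sits, and is the weakest of the three inhibitors shown. The steps read an at least 1.1-fold higher number from compound 1 to compound 2 (0.05 log units; that floor lies within the scatter), an at least 2.5-fold lower number from compound 2 to compound 3 (0.40 log units; beyond the scatter) and a 2.2-fold lower number from compound 1 to compound 3 (0.35 log units; beyond the scatter).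

Compound 4 `CC(C)[C@H](NC(=O)COc1cccc2ccccc12)C(=O)N[C@@H](CC(=O)O)C(=O)COc1c(Cl)cccc1Cl` is the new member. It differs from compound 2 by 2,6-dichlorophenyl in place of 2-nitrophenyl on an oxygen on a saturated carbon. For the measured compounds named here, the step that bears most directly on it is the one from compound 2 to compound 3, where a halogenated ring replaced the 2-nitrophenyl and the number fell; the step from compound 1 to compound 3 points the same way. A modest lowering in this assay is therefore expected, roughly an at least 1.6-fold lower number from compound 2 to compound 4 (0.22 log units; that floor lies within the scatter), though the limit for compound 2 leaves its true size open. Compound 4 is expected to give about 60000 nM, within a range from 20000 nM to 150000 nM.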

Compound 4, half-maximal inhibitory concentration: 3000 nM
Beside the measured number, compound 4's estimate is 20-fold (1.30 log units) above it; the measured number lies below the stated range.
By their numbers in this assay, from the lowest: compound 4; then compound 3; then compound 1. At a limit, above all of these: compound 2.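

The aryl group on an oxygen on a saturated carbon can move the number in this assay much further than the first three compounds showed, with a 13-fold lower number from compound 3 to compound 4 (1.12 log units; beyond the scatter) and a 29-fold lower number from compound 1 to compound 4 (1.47 log units; beyond the scatter). Against compound 2 the change reads as an at least 33-fold lower number from compound 2 to compound 4 (1.52 log units; beyond the scatter), and this size is only a floor, as compound 2 has a limit and not a measured number: the limit of > 100000 nM in this assay, at which 1 of the 4 values shown sits.

Compound 3 and compound 4 both carry halogens on the ring and still stand far apart, so the presence of halogen atoms alone does not set the number here. Still open, on these data alone, is whether the gain belongs to the chlorine atoms or to where they sit, which a 2,6-dimethylphenyl or a 4-chlorophenyl group on the same oxygen would help separate. Also open, as far as these compounds go, is whether the 2,6-dichlorophenyl gain would persist with a tetrazole in place of the carboxylic acid.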